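Urea series on the shared core: chloro to trifluoromethyl

A few compounds are considered here, and "the series" means these few. Any claim that something is new, unique, unknown or untested is made for them only; others in the source may bear on it.

Compound 1 `O=C(Nc1cccc(-n2cc(-c3ccncc3)c(-c3ccc(Cl)c(O)c3)n2)c1)Nc1ccc(Cl)c(Cl)c1` is the urea of the shared core; in a functional assay on M14 cells (Homo sapiens) for inhibition, read by sulforhodamine B assay, with a stated time of 48 h (on this read-out lower numbers stand for stronger inhibition of growth and higher numbers for weaker inhibition of growth), compound 1 gives 6970 nM, the highest of the two numbers in hand. Compound 3 `COc1cc(-c2nn(-c3cccc(NC(=O)Nc4cccc(C(F)(F)F)c4)c3)cc2-c2ccncc2)ccc1Cl` gives 1870 nM in this assay, the nearest number, lower by a gap beyond the scatter. Compound 2 `COc1cc(-c2nn(-c3cccc(NC(=O)c4ccc(Cl)c(C(F)(F)F)c4)c3)cc2-c2ccncc2)ccc1Cl` returns only a limit in this assay, > 32500 nM. Within the data shown here, the single measured step, an at least 17-fold lower number from compound 2 to compound 3 (1.24 log units; beyond the scatter), concerns the carbonyl side and does not touch the aryl position altered here. Compound 4 `O=C(Nc1cccc(-n2cc(-c3ccncc3)c(-c3ccc(Cl)c(O)c3)n2)c1)Nc1ccc(Cl)c(C(F)(F)F)c1` differs from compound 1 by trifluoromethyl in place of chloro on an aromatic carbon. Among the measured compounds shown here, no measured step bears on that exchange, so no change beyond the scatter is expected: for compound 4 the step of a 1.2-fold lower number from compound 1 to compound 4 (0.07 log units; within the scatter) is estimated, giving an expected 6000 nM with range 2500 nM to 15000 nM.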

Compound 4, concentration for total growth inhibition: 2770 nM
Beside the measured number, compound 4's estimate is 2.2-fold (0.34 log units) above it; the measured number falls inside the stated range.
By their numbers in this assay, from the lowest: compounds 3 and 4 (each within the scatter of the next); then compound 1. At a limit, above all of these: compound 2.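

On the shared core, the aromatic carbon ortho to a chloro group is sensitive to substitution: trifluoromethyl in place of chloro gives a 2.5-fold lower number from compound 1 to compound 4 (0.40 log units; beyond the scatter) in this assay. Among these compounds, this is the first measured step at this position, and it shows that the larger trifluoromethyl group is accepted here without loss of growth inhibition. Nothing measured for these compounds accounts for the step.

Going by these compounds, it remains open how a nitrile, an amine or a carboxylic acid on this aromatic carbon would read. A single exchange also leaves open whether the step would carry over to other urea partners.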